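The compounds below may be only part of what the source reports. "The series", "measured", "known", "first", "only" and "open" are said of these compounds alone.

Measured in a physicochemical assay for lipophilicity, using the shake flask method, in phosphate buffer, measured as octanol-water partition, with a stated time of 30 min, at pH 7.4; a lower number here means a more polar compound, a higher number a more lipophilic compound:
- compound 1 `Cc1ncccc1-c1cnc(NCc2c(F)ccc3c2CCO3)c2nn(CC#N)c(=O)n12`: 2.2
- compound 2 `Fc1ccc2c(c1CNc1ncc(Oc3ccccc3)c3nncn13)CCO2`: 3.5
- compound 3 `Cc1nc(CO)ccc1-c1cnc(NCc2c(F)ccc3c2CCO3)c2cn[nH]c(=O)c12`: 2.4

Compound 3, at 2.4, lies within the scatter of compound 1, and the two form the lower pair of the three. Compound 2, at 3.5, stands beyond the scatter above compound 3.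

Compound 4 `CN(C)C(=O)c1cc(-c2cnc(NCc3c(F)ccc4c3CCO4)c3cn[nH]c(=O)c23)n(C)n1` has not yet been measured. It differs from compound 3 in one place: 3-(dimethylcarbamoyl)-1-methyl-1H-pyrazol-5-yl in place of 6-(hydroxymethyl)-2-methylpyridin-3-yl on an aromatic carbon. 3-(dimethylcarbamoyl)-1-methyl-1H-pyrazol-5-yl stands in place of 6-(hydroxymethyl)-2-methylpyridin-3-yl on an aromatic carbon. Going by the values given here, the hydrogen-bond donor of the leaving group has no counterpart in the entering group, which carries one more hydrogen-bond acceptor.

Among the compounds with values here, no two measured compounds differ in only one place, so the series offers no direct precedent for this change. The expectation in this assay is therefore anchored on compound 3 at 2.4, with no step beyond the scatter and no firm direction. The estimated change is a number 0.10 log units lower from compound 3 to compound 4 (within the scatter). For compound 4 the expected value is 2.3, with an estimated range of 1.8 to 2.8.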

Compound 4, distribution coefficient: 2.1
Beside the measured number, compound 4's estimate is 0.20 log units above it, and the stated range covers the measured number.
By their numbers in this assay, from the lowest: compounds 4, 1 and 3 (each within the scatter of the next); then compound 2.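

Going by these compounds alone, the step of a number 0.30 log units lower from compound 3 to compound 4 (within the scatter) is the first to change one place only, and it is read in this assay at the aromatic carbon para to a large group. It shows that 3-(dimethylcarbamoyl)-1-methyl-1H-pyrazol-5-yl can stand in place of 6-(hydroxymethyl)-2-methylpyridin-3-yl without a shift beyond the scatter, although the entering group has a five-membered ring and no hydrogen-bond donor. No measurement at hand bears on the reason for this result.

The ring, the dimethylcarbamoyl group and the hydroxymethyl group change together in this step, so their separate contributions remain unresolved. From the compounds shown here alone, how a carboxylic acid or an aminomethyl group would read at this position also remains open.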